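Swapping the aryl group on the carbonyl of a shared core

This account rests on a few compounds, and the source may have more. Where it says the series, first, only, none or still open, it means among the compounds named here.

Compound 2 `Cc1cs/c(=N\C(=O)c2ccccc2Cl)n1-c1cc(Cl)c(Cl)cc1Cl` gives 100 nM in an assay on isolated protein for inhibition of Alpha glucosidase (Homo sapiens), with stated times of 5 min and 30 min; on this read-out higher numbers stand for weaker inhibition and lower numbers for stronger inhibition. Compound 1 `COc1ccc(C(=O)/N=c2\scc(C)n2-c2cc(Cl)c(Cl)cc2Cl)cc1` gives 100 nM in this assay, so compound 2 stands level with compound 1, the step of no change at the digits printed from compound 1 to compound 2 (within the scatter) lying within the scatter. Compound 3 `Cc1cccc(C(=O)/N=c2\scc(C)n2-c2cc(Cl)c(Cl)cc2Cl)c1` carries the change (3-methylphenyl in place of 2-chlorophenyl on a carbonyl carbon). Among the compounds with values here, only the step from compound 1 to compound 2 bears on this change, and it showed no shift beyond the scatter, so the expected step of no change at the digits printed from compound 2 to compound 3 (within the scatter) is also none beyond the scatter. Compound 3 is therefore expected to give about 100 nM in this assay, somewhere between 40 nM and 250 nM.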

Compound 3, half-maximal inhibitory concentration: 100 nM
Compound 3: the middle estimate sits on the measured number at the digits printed; low and high end bracket the measured number.
By their numbers in this assay, from the lowest: compounds 1, 2 and 3 (each within the scatter of the next).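

In this assay, 3-methylphenyl in place of 2-chlorophenyl gives no change at the digits printed from compound 2 to compound 3 (within the scatter) and, set against 4-methoxyphenyl, gives no change at the digits printed from compound 1 to compound 3 (within the scatter) as well. A third phenyl ring, now carrying only carbon as its added group, therefore reads the same on this carbonyl carbon, so neither chlorine nor methoxy on this ring is needed to match these values. No available measurement explains why the values match. Going by these compounds, all three compounds keep a substituted phenyl ring here, so the limits of this position remain unknown. A phenyl ring carrying an amine or a carboxylic acid, or a longer alkyl chain replacing the ring, could behave differently.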